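Glucagon receptor series: methoxy for hydroxymethyl on the aryl

The source may report more compounds than this note shows. Statements on the series, on what has been measured and on what is new or still open speak of the compounds shown alone.

Measured so far:
- compound 1 `CCCCCc1c(C(C)C)nc(C(C)C)c(CO)c1-c1ccc(O)cc1`: 24%
- compound 2 `CCCCCc1c(C(C)C)nc(C(C)C)c(CO)c1-c1cccc(Cl)c1`: 49%
- compound 3 `CCCCCc1c(C(C)C)nc(C(C)C)c(CO)c1-c1ccccc1CO`: 44%

In an assay on CHO cells for inhibition of Glucagon receptor (Homo sapiens), tested at 20 uM (on this read-out higher numbers stand for more inhibition at the one concentration tested (going by the name of the read-out) and lower numbers for less inhibition), compound 3 gives 44%, the second highest of the three numbers. Its nearest neighbour is compound 2, where a number 5 percentage points lower from compound 2 to compound 3 (within the scatter); the furthest is compound 1, where a number 20 percentage points higher from compound 1 to compound 3 (beyond the scatter). The change to compound 4 `CCCCCc1c(C(C)C)nc(C(C)C)c(CO)c1-c1ccccc1OC` is methoxy in place of hydroxymethyl on an aromatic carbon, placed ortho to a large group. For the measured compounds named here, only two measured steps touch the same aryl group: a number 20 percentage points higher from compound 1 to compound 3 (beyond the scatter) and a number 25 percentage points higher from compound 1 to compound 2 (beyond the scatter), both modest, and a number 5 percentage points lower from compound 2 to compound 3 (within the scatter), which is within the scatter. Going by the values given here, none of them swaps hydroxymethyl for methoxy, so there is no direct precedent for this change. Because a number 5 percentage points lower from compound 2 to compound 3 (within the scatter) shows that quite different groups on this ring give similar numbers, the expected step of a number 2 percentage points lower from compound 3 to compound 4 (within the scatter) is small and within the scatter, with no clear direction. Compound 4 is therefore estimated at 42%, with a range from 25% to 60%.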

Compound 4, a percentage reported as inhibition, at one concentration (the size of the read-out at that concentration, not a potency): 27%
For compound 4 the middle estimate is 15 percentage points above the measured one, and the stated range covers the measured number.
By their numbers in this assay, from the lowest: compounds 1 and 4 (each within the scatter of the next); then compounds 3 and 2 (each within the scatter of the next).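

In this assay, methoxy in place of hydroxymethyl, on an aromatic carbon ortho to a large group, gives a number 17 percentage points lower from compound 3 to compound 4 (beyond the scatter), so this position tells apart two groups made of the same atoms joined differently. The earlier near-match of 3-chlorophenyl and 2-(hydroxymethyl)phenyl therefore does not extend to every aryl group: 2-methoxyphenyl in place of 3-chlorophenyl gives a number 22 percentage points lower from compound 2 to compound 4 (beyond the scatter), whereas 2-methoxyphenyl in place of 4-hydroxyphenyl gives a number 3 percentage points higher from compound 1 to compound 4 (within the scatter). Nothing available explains why hydroxymethyl and methoxy differ here.

Still open, from the compounds shown here alone, is how an aminomethyl group or a carboxylic acid would read at this position, and whether ethoxy would track methoxy. With one concentration per compound, the series also leaves the potency order of these compounds undefined.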